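Methoxy on the Benzylic Carbon of a Chromone Core

The source may hold more compounds than are shown below. What is called first, only, known or untested is meant among the compounds shown, and "the series" means these compounds.

Measured compounds:
- compound 1, `Cc1c(F)c(N)c2c(=O)cc(-c3ccc(N)c(F)c3)oc2c1F`: 13 nM
- compound 2, `CN(C)CC(=O)OCc1c(F)c(N)c2c(=O)cc(-c3ccc(N)c(F)c3)oc2c1F`: 26 nM

Compound 1 has the lowest number of the two compounds tested in a functional assay on MCF7 cells (Homo sapiens) for cytotoxicity, read by neutral red uptake, with a stated time of 3 days (on this read-out higher numbers stand for weaker inhibition and lower numbers for stronger inhibition), though its nearest neighbour, compound 2, sits within the usual scatter of it: the step of a 2.0-fold higher number from compound 1 to compound 2 (0.30 log units; within the scatter) is too small to count as a real change.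

Compound 3 is `COCc1c(F)c(N)c2c(=O)cc(-c3ccc(N)c(F)c3)oc2c1F`. For the measured compounds named here, it differs from compound 1 in one place, (methoxy in place of hydrogen on a saturated chain carbon bound to an aromatic carbon), a smaller substituent entering at the same saturated chain carbon where compound 2 carries its larger ((dimethylamino)methyl)carbonyl)oxy group. The only step that bears on it is that from compound 1 to compound 2, which stayed within the scatter. A substitution at that position therefore gives no reason to expect a large movement, and for compound 3 an expected step of a 1.4-fold higher number from compound 1 to compound 3 (0.14 log units; within the scatter) in this assay is estimated. The estimate for compound 3 is 18 nM, with a range from 7 nM to 45 nM.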

Compound 3, half-maximal inhibitory concentration: 46 nM
For compound 3 the middle estimate is 2.6-fold (0.41 log units) below the measured one; measured number outside the range, above it.
By their numbers in this assay, from the lowest: compounds 1, 2 and 3 (each within the scatter of the next, the first and the last beyond it).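

Methoxy in place of hydrogen on the saturated chain carbon bound to an aromatic carbon is the first change at this carbon to pass beyond the scatter in this assay with a modest step (a 3.5-fold higher number from compound 1 to compound 3 (0.55 log units; beyond the scatter)). Methyl in place of ((dimethylamino)methyl)carbonyl on the oxygen stays within the scatter (a 1.8-fold higher number from compound 2 to compound 3 (0.25 log units; within the scatter)), so compound 2 and compound 3 cannot be told apart, and only compound 1 and compound 3 separate. No measurement shown speaks to the reason for this step.

Open, from the compounds shown here alone, is whether the oxygen or its methyl carries the step, a question a hydroxy group on that carbon would address. Also open, going by these compounds, is how an ethoxy group or a dimethylamino group set directly on that carbon would compare with compound 1.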